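This account rests on a few compounds, and the source may have more. Where it says the series, first, only, none or still open, it means among the compounds named here.

Working notes on the endoperoxide series.

Three compounds have numbers in a functional assay on SF-539 cells (Homo sapiens) for inhibition; a higher number here means a weaker inhibitor of growth, a lower number a stronger inhibitor of growth. Compound 1, `COC(=O)[C@H](C)[C@H]1CC[C@@](C)(CCC2=C(C)CCCC2(C)C)OO1`, reaches only a limit there: in this assay compound 1 gives > 25000 nM, which is a limit of the measurement and not a number, as recorded in the limit of > 25000 nM in this assay, at which 1 of the 3 values shown sits. Compound 3, `CC1=C(CC/C(C)=C/CC[C@@]2(C)CC[C@H]([C@H](C)C(=O)O)OO2)C(C)(C)CCC1`, likewise stops at a limit: in this assay compound 3 gives > 5000 nM, again a limit rather than a number, as in the limit of > 5000 nM in this assay, at which 1 of the 3 values shown sits. Compound 2, `C=C1CCC[C@H]2[C@](C)(CC[C@]3(C)CC[C@H]([C@@H](C)C(=O)O)OO3)[C@@H](C)CC[C@]12C`, is the one member with a proper value; in this assay compound 2 gives 1610 nM, and on the numbers shown it is the only compound with a measured figure.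

Compound 4, `C=C1CCC[C@H]2[C@](C)(CC[C@]3(C)CC[C@@H]([C@@H](C)C(=O)O)OO3)[C@@H](C)CC[C@]12C`, is not yet measured. Relative to compound 2 the change is the two compounds have the same atoms and bonds and differ only in configuration as drawn: 1 of 7 stereo elements differ; a stereocentre at a saturated ring carbon is drawn R in compound 2 and S in compound 4. For the measured compounds named here, no measured pair in the set turns on a single configuration, so nothing here sets a scale for this kind of step. The step from compound 2 to compound 4 is expected to be a 1.9-fold higher number from compound 2 to compound 4 (0.27 log units; within the scatter), with the direction left open. Compound 4 is therefore estimated at 3000 nM, in a range from 800 nM to 12000 nM.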

Compound 4, concentration for 50% growth inhibition: 1070 nM
For compound 4 the middle estimate is 2.8-fold (0.45 log units) above the measured one; the range from low to high includes it.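

A single inversion at the saturated ring carbon gives a 1.5-fold lower number from compound 2 to compound 4 (0.18 log units; within the scatter) in this assay. For the compounds shown here, this is the first pair that turns on one configuration, so this kind of step now has a size, though only for this carbon and this core. The step can be read as one of configuration alone: the fact that compounds 2 and 4 differ only in the configuration as drawn.

On these data alone, whether the inversion reads the same way on another core stays open, as compound 1 and compound 3 each give only a limit of the assay and differ from compound 2 in more than one place. Also open, as far as these compounds go, is how a primary amide in place of the carboxylic acid of compound 2 and compound 4 would read in this assay.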